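From a nitro group to a piperazinyl sulfonyl

This account rests on a few compounds, and the source may have more. Where it says the series, first, only, none or still open, it means among the compounds named here.

Measured so far:
compound 1 `C#CCN(Cc1ccc2nc(C)nc(O)c2c1)c1ccc([N+](=O)[O-])cc1`: 4700 nM
compound 2 `C#CCN(Cc1ccc2nc(C)nc(O)c2c1)c1ccc([N+](=O)[O-])c(C(F)(F)F)c1`: 5000 nM

For the measured compounds named here, in a functional assay on L1210 cells (Mus musculus) for inhibition (on this read-out higher numbers stand for weaker inhibition and lower numbers for stronger inhibition), compound 1 gives 4700 nM, the lowest of the two numbers; its only neighbour is compound 2, reached by a 1.1-fold higher number from compound 1 to compound 2 (0.03 log units; within the scatter). Compound 3 `C#CCN(Cc1ccc2nc(C)nc(O)c2c1)c1ccc(S(=O)(=O)N2CCN(C)CC2)cc1` differs from compound 1 in one place: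
(4-methylpiperazin-1-yl)sulfonyl in place of nitro on an aromatic carbon
Going by the values given here, the single measured step, trifluoromethyl in place of hydrogen on an aromatic carbon, adds a small group beside the nitro and stays within the scatter; it does not involve the nitro itself and so gives no guide to its replacement by a (4-methylpiperazin-1-yl)sulfonyl. Among the compounds with values here, with no comparable step available, compound 3 is expected to give a number near that of compound 1, with a wide range in either direction. Compound 3 is estimated at 6000 nM, between 1500 nM and 25000 nM, which means a 1.3-fold higher number from compound 1 to compound 3 (0.11 log units; within the scatter) is expected in this assay.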

Compound 3, half-maximal inhibitory concentration: > 10000 nM
Compound 3: only a limit was reported; the forecaster's own chance of this, stated with the estimate: 15%; middle value at least 1.6-fold (0.22 log units) from the limit.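

In this assay compound 3 gives > 10000 nM, which is a limit of the assay and not a number. Replacing nitro at this position, on an aromatic carbon para to a large group, gives an at least 2.1-fold higher number from compound 1 to compound 3 (0.32 log units; beyond the scatter), so this position responds to a change of group towards weaker inhibition, whereas the earlier trifluoromethyl step stayed within the scatter. How much weaker remains undefined at the upper end: the limit of > 10000 nM in this assay, at which 1 of the 3 values shown sits.

The compounds shown leave open whether this shift belongs to the sulfonyl itself or to the 4-methylpiperazine ring it carries; a simple methylsulfonyl group or a nitrile on this carbon would help to separate the two. Also open, from the compounds shown here alone, is whether a free amine or a carboxylic acid on this carbon would be tolerated as well as nitro is in compound 1.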